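The compounds below may be only part of what the source reports. "The series", "measured", "known", "first", "only" and "open" are said of these compounds alone.

Measured so far:
Compound 1, `CC(C)CN(Cc1ccc(C(=O)NO)cc1)C(=O)Nc1ccccc1`: 12 nM
Compound 2, `O=C(O)c1ccc(CN(CCCCO)C(=O)Nc2ccccc2)cc1`: "not active" (no number reported)
Compound 3, `CCCCN(Cc1ccc(N(O)C=O)cc1)C(=O)Nc1ccccc1`: 1030 nM

In an assay on Sf9 cells for inhibition of protein deacetylase HDAC6 (Homo sapiens), read by fluorescence, with stated times of 10 min and 2 h (a lower number here means a stronger inhibitor, a higher number a weaker inhibitor), compound 1 gives 12 nM, while compound 2 gives "not active" (no number reported) and compound 3 gives 1030 nM. Compound 3 therefore stands at the highest of the two numbers reported, and its nearest neighbour, compound 1, sits far lower, a gap well beyond the scatter; compound 2 returned no number at all.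

Compound 4, `CCCCN(Cc1ccc(/C(N)=N/O)cc1)C(=O)Nc1ccccc1`, is not yet measured. It differs from compound 3 in a single place: a group of 4 heavy atoms (1 carbon, 2 nitrogen, 1 oxygen; no ring) in place of a group of 4 heavy atoms (1 carbon, 1 nitrogen, 2 oxygen; no ring), on an aromatic carbon. The shared core stays the same. Going by the values given here, no measured pair shows this exact change, so the expectation rests on the spread of the three compounds alone. Compound 2 gave "not active" (no number reported) and compound 3 already gives 1030 nM, which together frame the outlook. The step of a 7.8-fold higher number from compound 3 to compound 4 (0.89 log units; beyond the scatter) is expected, toward weaker inhibition and beyond the scatter, with a real chance that only a limit is returned. Compound 4 is expected to give 8000 nM, in a range from 2000 nM to 40000 nM.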

Compound 4, half-maximal inhibitory concentration: "not active" (no number reported)
Nothing numeric was reported for compound 4; no gap can be computed for the estimate.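

Compound 4 gives "not active" (no number reported), so no size can be put on the change from compound 3 to compound 4. No measurement shown here offers a reason for this result. The compounds shown leave open how much a change in one place alters inhibition in numbers.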